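Macrophage Tolerance of Three Closely Related Compounds

A few compounds are considered here, and "the series" means these few. Any claim that something is new, unique, unknown or untested is made for them only; others in the source may bear on it.

Measured so far:
compound 1 `CC1(Cc2cccc(/C(N)=N/O)c2)CC(S(=O)(=O)c2ccc(F)cc2)=C(c2ccc(/C(N)=N/O)cc2)O1`: 50200 nM
compound 2 `CC1(Cc2cc(C(F)(F)F)cc(C(F)(F)F)c2)CC(S(=O)(=O)c2ccc(F)cc2)=C(c2ccc(/C(N)=N/O)cc2)O1`: 43100 nM

Of the compounds shown here, two have been tested in an ADME assay on cells (Peritoneal macrophage, Mus musculus, strain Balb/c) for cytotoxicity, read by resazurin assay, with a stated time of 72 h; a lower number here means that less compound is tolerated, a higher number that more compound is tolerated. Compound 1 gives 50200 nM, the higher of the two numbers recorded, while compound 2 gives 43100 nM. Among the compounds with values here, the two values lie within the scatter of each other, so nothing can be read from their order, and no step between them is on record.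

The next compound, compound 3 `CC1(Cc2cccc([N+](=O)[O-])c2)CC(S(=O)(=O)c2ccc(F)cc2)=C(c2ccc(/C(N)=N/O)cc2)O1`, has not yet been tested in this assay. It differs from compound 1 at a single point: a group of 3 heavy atoms (1 nitrogen, 2 oxygen; no ring) in place of a group of 4 heavy atoms (1 carbon, 2 nitrogen, 1 oxygen; no ring), on an aromatic carbon. The rest of the shared core is untouched.

Within the data shown here, since no measured pair shows what this kind of exchange does, the expectation for compound 3 rests on the two numbers above, which are close to each other even though compound 1 and compound 2 differ considerably on the same ring. Compound 3 is expected to give 45000 nM in this assay, with a range from 25000 nM to 85000 nM. The estimate implies a step of a 1.1-fold lower number from compound 1 to compound 3 (0.05 log units; within the scatter), which is expected to stay within the scatter.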

Compound 3, half-maximal cytotoxic concentration: 86600 nM
The estimate for compound 3 lay 1.9-fold (0.28 log units) below the measured number; the measured number lies above the stated range.
By their numbers in this assay, from the lowest: compounds 2, 1 and 3 (each within the scatter of the next).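

In this assay, placing nitro on this aromatic carbon, meta to a large group, in place of the group of 4 heavy atoms gives a 1.7-fold higher number from compound 1 to compound 3 (0.24 log units; within the scatter) and so stays within the scatter. Within the data shown here, this single-place step is the first on record at this position, and it shows that the number does not move beyond the scatter when a group with 2 hydrogen-bond donors gives way to one with 0 hydrogen-bond donors, while the count of 2 hydrogen-bond acceptors stays the same. Nothing on record bears on the reason for this outcome.

Among these compounds, compound 1 and compound 3 give only one exchange at this place, so it remains open whether an amine, a carboxylic acid or a longer chain on the same aromatic carbon would also stay within the scatter or would take the number clearly away from that of compound 1. Among the compounds shown here, it also remains open whether nitro would give a similar step if another part of the shared core were changed, since the single step here was taken with everything else held constant.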